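Shortening the Chain Behind the Methylpiperazine Carbamate

The source may hold more compounds than are shown below. What is called first, only, known or untested is meant among the compounds shown, and "the series" means these compounds.

Compound 3 `CN(C)CCCCCOC(=O)Nc1cccc(Cn2nc(-n3ccc4ccc(F)cc43)ccc2=O)c1` carries a carbamate whose chain ends in a dimethylamino group. In a functional assay on EBC-1 cells (Homo sapiens) for inhibition, read by sulforhodamine B assay, with a stated time of 72 h (a higher number here means a weaker inhibitor, a lower number a stronger inhibitor), compound 3 gives <= 100 nM, a limit of the assay rather than a number. Compound 1 `CN1CCN(CCCCCOC(=O)Nc2cccc(Cn3nc(-n4ccc5ccc(F)cc54)ccc3=O)c2)CC1` differs from it only in the amine at the end of the chain; in this assay compound 1 gives <= 1000 nM, again a limit. Compound 2 `CN(C)CCCCOC(=O)Nc1cccc(Cn2nc(-n3ccc4ccc(F)cc43)ccc2=O)c1` has a shorter chain; in this assay compound 2 gives <= 1000 nM, also a limit. All the evidence is thus the limit of <= 1000 nM in this assay, at which 2 of the 3 values shown sit, and (the limit of <= 100 nM in this assay, at which 1 of the 3 values shown sits), and the steps a step that the two limits leave unreadable from compound 1 to compound 3, a step that the two limits leave unreadable from compound 2 to compound 3 and a step that the two limits leave unreadable from compound 1 to compound 2 stay unreadable.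

Compound 4 `CN1CCN(CCCCOC(=O)Nc2cccc(Cn3nc(-n4ccc5ccc(F)cc54)ccc3=O)c2)CC1` is reached from compound 3 by 4-methylpiperazin-1-yl in place of (dimethylamino)methyl on a saturated chain carbon, four bonds along the chain from an oxygen next to a carbonyl group. The measured steps that bear on this change have no readable size and no direction, so no step beyond the scatter can be predicted in either sense. Compound 4 is therefore expected near 200 nM, between 30 nM and 1500 nM. The expected step is an at least 2.0-fold higher number from compound 3 to compound 4 (0.30 log units; that floor lies within the scatter).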

Compound 4, half-maximal inhibitory concentration: <= 100 nM
Compound 4 ended at the assay's limit; the forecaster's own chance of this, stated with the estimate: 70%; middle value at least 2.0-fold (0.30 log units) from the limit.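

Compound 4, like compound 1, compound 2 and compound 3, stands at a limit of the assay, and none of its steps from those three compounds can be read. The compounds shown leave open whether the terminal amine or the chain length alters potency in this assay.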